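Acetyl in Place of Chloro: Compound 4 Expected at the Limit

A few compounds are considered here, and "the series" means these few. Any claim that something is new, unique, unknown or untested is made for them only; others in the source may bear on it.

Measured compounds in a functional assay on SMMC-7721 cells (Homo sapiens) for cytotoxicity, read by MTT assay, with a stated time of 72 h; on this read-out lower numbers stand for stronger inhibition and higher numbers for weaker inhibition:
Compound 1 `O=C(CSC(=S)N[C@H]1CCOC1=O)Nc1ccc(Cl)cc1` gives only a limit, > 128000 nM.
Compound 2 `Cc1cccc(NC(=O)CSC(=S)N[C@H]2CCOC2=O)c1` gives only a limit, > 128000 nM.
Compound 3 `O=C(CSC(=S)N[C@H]1CCOC1=O)Nc1ccc(Cl)cc1Cl` gives only a limit, > 128000 nM.

Compound 1 therefore stands at the limit of > 128000 nM in this assay, at which 3 of the 3 values shown sit, with no number of its own. Compound 4 `CC(=O)c1ccc(NC(=O)CSC(=S)N[C@H]2CCOC2=O)cc1` differs from it by acetyl in place of chloro on an aromatic carbon. The two measured steps that start from compound 1 are a step that the two limits leave unreadable from compound 1 to compound 2 and a step that the two limits leave unreadable from compound 1 to compound 3; both run between limits and show nothing about size or direction. Every change of the aromatic substituent seen so far has left the read-out at the limit, so no step beyond the scatter is expected in this assay for compound 4 either. Compound 4 is accordingly estimated at 200000 nM, between 60000 nM and 1000000 nM, most probably reported again as a limit, which corresponds to an expected step that the limit leaves unreadable from compound 1 to compound 4.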

Compound 4, half-maximal inhibitory concentration: > 128000 nM
Compound 4 was reported as a limit; the forecaster's own chance of this, stated with the estimate: 80%; the middle value does not contradict the limit.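

In this assay compound 4, like compound 1, gives only a limit, so no step between them can be read: the limit of > 128000 nM in this assay, at which 4 of the 4 values shown sit.

The compounds shown leave open whether any change of aromatic substituent on the shared core moves the read-out at all.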